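The source may hold more compounds than are shown below. What is called first, only, known or untested is meant among the compounds shown, and "the series" means these compounds.

For the measured compounds named here, the three compounds measured so far share one core and differ only in the group carried on the saturated chain carbon bound to an aromatic nitrogen. Compound 1 `Cc1ccc(Cn2cc(COc3ccc4c(=O)ccoc4c3)nn2)cc1`, compound 2 `O=c1ccoc2cc(OCc3cn(Cc4ccc(Cl)cc4)nn3)ccc12` and compound 3 `O=c1ccoc2cc(OCc3cn(Cc4cccc(Br)c4)nn3)ccc12` were all tested in an ADME assay on L02 cells (Homo sapiens) for cytotoxicity, read by MTT assay, with a stated time of 48 h; a lower number here means a stronger inhibitor, a higher number a weaker inhibitor. Compound 1 gives only a limit, > 300000 nM. Compound 2 likewise gives only a limit, > 300000 nM. Compound 3 too gives only a limit, > 300000 nM. Because all three values sit at the limit of > 300000 nM in this assay, at which 3 of the 3 values shown sit, none of the steps between them can be read: the step that the two limits leave unreadable from compound 1 to compound 2, the step that the two limits leave unreadable from compound 1 to compound 3 and the step that the two limits leave unreadable from compound 2 to compound 3 all remain without a size. Compound 4 `O=c1ccoc2cc(OCc3cn(Cc4cccc([N+](=O)[O-])c4)nn3)ccc12` is the next member; it differs from compound 3 by nitro in place of bromo on an aromatic carbon. Going by the values given here, no measured step gives a size for such a change, so the only guide is where compound 3 stands. For compound 4 the expected step is a step that the limit leaves unreadable from compound 3 to compound 4, nothing beyond the scatter. Compound 4 is estimated at 400000 nM, in the range from 120000 nM to 1500000 nM, and is most likely to be reported again only as a limit.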

Compound 4, half-maximal inhibitory concentration: > 300000 nM
Compound 4 ended at the assay's limit; the forecaster's own chance of this, stated with the estimate: 85%; the middle value does not contradict the limit.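

The steps from compound 1, compound 2 and compound 3 to compound 4 cannot be read, because all four compounds share one limit rather than a number: the limit of > 300000 nM in this assay, at which 4 of the 4 values shown sit. The compounds shown leave open how the groups compare in cytotoxicity, including nitro against bromo.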